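A Two-Ring Group Replaces the Phenylethyl Arm

The source may hold more compounds than are shown below. What is called first, only, known or untested is meant among the compounds shown, and "the series" means these compounds.

Measured so far:
compound 1 `C[C@H](c1cc(F)c(F)c(F)c1)N(C(=O)c1ccccc1)[C@@H](C(N)=O)c1ccccc1`: 1700 nM
compound 2 `C[C@H](c1ccccc1)N(C(=O)c1ccccc1)[C@@H](C(N)=O)c1ccccc1`: 1200 nM

Among the compounds with values here, in an assay on HEK293T cells for antagonist activity at transient receptor potential cation channel subfamily M member 8 (Homo sapiens), read by fluorescence and calcium flux, with a stated time of 60 min (on this read-out lower numbers stand for stronger inhibition and higher numbers for weaker inhibition), compound 2 gives the lowest of the two numbers, yet its only neighbour differs by a 1.4-fold lower number from compound 1 to compound 2 (0.15 log units; within the scatter), so the two compounds cannot be told apart on these figures. Compound 3 `NC(=O)[C@@H](c1ccccc1)N(C(=O)c1ccccc1)[C@@H]1CCc2ncccc21` changes the arm on the amide-type nitrogen: a group of 9 heavy atoms (8 carbon, 1 nitrogen; one five-membered non-aromatic ring of carbon only, one six-membered aromatic ring with 1 hetero atom) in place of a group of 8 heavy atoms (8 carbon; one six-membered aromatic ring of carbon only), on an amide-type nitrogen. Within the data shown here, the single measured step, a 1.4-fold lower number from compound 1 to compound 2 (0.15 log units; within the scatter), concerns only the fluorine pattern on that same arm and stays within the scatter; no measured step replaces the arm itself, so there is no precedent for a move of this kind. The expectation for compound 3 therefore rests on compound 2 alone, with a step of a 1.3-fold higher number from compound 2 to compound 3 (0.10 log units; within the scatter) expected and a wide band of uncertainty. Compound 3 is estimated at 1500 nM, within 300 nM to 8000 nM.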

Compound 3, half-maximal inhibitory concentration: 19500 nM
Estimate against measurement, compound 3: 13-fold (1.11 log units) below, outside the stated range (above it).
By their numbers in this assay, from the lowest: compounds 2 and 1 (each within the scatter of the next); then compound 3.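

In this assay, the arm on the amide-type nitrogen now proves sensitive to replacement: exchanging 1-phenylethyl for the group with a five-membered non-aromatic ring and a nitrogen-containing six-membered aromatic ring gives a 16-fold higher number from compound 2 to compound 3 (1.21 log units; beyond the scatter). Within the data shown here, the only earlier step, from compound 1 to compound 2, removed fluorine from the ring of that arm and stayed within the scatter, so it gave no sign that this position could respond so strongly. Nothing available here explains the weaker inhibition of compound 3.

The change alters several things at once, so the compounds shown cannot separate the effect of the ring nitrogen from that of the closed five-membered ring. An indan-1-yl arm, which keeps both rings with carbon only, and a 1-(pyridinyl)ethyl arm, which keeps the ring nitrogen on an open chain, would pull these two features apart.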